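The compounds below may be only part of what the source reports. "The series", "measured", "known", "first", "only" and "open" are said of these compounds alone.

Measured compounds:
compound 1, `COc1ccc(NCc2nc3ccccc3[nH]2)cc1`, 7.6%;
compound 2, `Cc1ccc(NCc2nc3ccc(Br)cc3[nH]2)cc1`, 7.6%;
compound 3, `O=[N+]([O-])c1ccc2nc(CNc3ccc(Br)cc3)[nH]c2c1`, 15.3%.

In a functional assay on the whole organism (strain albino) for inhibition, with Rattus norvegicus as the target, read by paw edema, with a stated time of 30 min, at a dose of 100 mg/kg by the oral route (on this read-out higher numbers stand for more inhibition at the one dose given (going by the name of the read-out) and lower numbers for less inhibition), compound 2 stands level with compound 1 at the digits shown, and the two are together the lowest of the three numbers. Compound 3 reads somewhat higher, but that gap lies within the scatter, so no order among the three can be claimed.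

Compound 4, `Brc1ccc2nc(CNc3ccccc3)[nH]c2c1`, has not been measured. It differs from compound 2 in one place: hydrogen in place of methyl on an aromatic carbon. Within the data shown here, no step between measured compounds is available to guide this change. As nothing here points either way, the expected step of a number 0.4 percentage points higher from compound 2 to compound 4 (within the scatter) is none beyond the scatter. Compound 4 is therefore estimated at 8%, within a range from 0% to 20%.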

Compound 4, a percentage reported as inhibition, in the whole organism at one dose (the size of the read-out at that dose, not a potency): 7.6%
Compound 4: middle estimate off by 0.4 percentage points, on the high side; the measured number falls inside the stated range.
By their numbers in this assay, from the lowest: compounds 1, 2, 4 and 3 (each within the scatter of the next).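

Hydrogen in place of methyl on an aromatic carbon, para to a large group, gives no change at the digits printed from compound 2 to compound 4 (within the scatter) in this assay. Among these compounds, this is the first comparison here of compounds that differ in one place, and it shows that in this bromine-bearing series the methyl group can go without any change beyond the scatter. Nothing at hand offers a reason for this result.

On these data alone, whether an amine, a carboxylic acid or a longer chain on this same carbon would move the number beyond the scatter stays open. So does whether methyl and hydrogen would also read alike on another core.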